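A few compounds are considered here, and "the series" means these few. Any claim that something is new, unique, unknown or untested is made for them only; others in the source may bear on it.

Among the compounds with values here, compound 3 `COc1cccc(N2CCN(C(=O)c3oc(C)nc3-c3ccccc3)CC2)c1` gives 34.8 nM in a functional assay on HL-60 cells (Homo sapiens) for inhibition, read by MTT assay, with a stated time of 72 h (on this read-out lower numbers stand for stronger inhibition and higher numbers for weaker inhibition), the lowest of the three numbers so far. Compound 1 `Cc1nc(-c2ccccc2)c(C(=O)N2CCN(c3cccc(C)c3C)CC2)o1` gives 35 nM in this assay, and a 1.0-fold lower number from compound 1 to compound 3 (0.00 log units; within the scatter). Compound 2 `COc1cccc(N2CCN(C(=O)c3oc(C)nc3-c3ccc(F)cc3)CC2)c1` gives 112 nM in this assay, and a 3.2-fold lower number from compound 2 to compound 3 (0.51 log units; beyond the scatter).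

Compound 4 `Cc1nc(-c2ccccc2)c(C(=O)N2CCN(c3ccc(Cl)c(Cl)c3)CC2)o1` has not yet been measured. It differs from compound 3 in one place: 3,4-dichlorophenyl in place of 3-methoxyphenyl on an amine nitrogen in a ring. Of the two measured steps, only a 1.0-fold lower number from compound 1 to compound 3 (0.00 log units; within the scatter) concerns the same place, the group on the amine nitrogen in a ring, and that exchange left the number unchanged within the scatter. The other step, a 3.2-fold lower number from compound 2 to compound 3 (0.51 log units; beyond the scatter), concerns a different part of the molecule and offers no guidance on this exchange. Within the data shown here, the one comparison that applies therefore points to no step beyond the scatter in this assay, with the usual uncertainty of a single precedent. For compound 4 a value of 40 nM is expected, within a range from 15 nM to 120 nM. This estimate implies an expected step of a 1.1-fold higher number from compound 3 to compound 4 (0.06 log units; within the scatter).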

Compound 4, half-maximal inhibitory concentration: 124 nM
The estimate for compound 4 lay 3.1-fold (0.49 log units) below the measured number; the measured number lies above the stated range.
By their numbers in this assay, from the lowest: compounds 3 and 1 (each within the scatter of the next); then compounds 2 and 4 (each within the scatter of the next).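

In this assay the group on the amine nitrogen in a ring turns out to matter: 3,4-dichlorophenyl in place of 3-methoxyphenyl gives a 3.6-fold higher number from compound 3 to compound 4 (0.55 log units; beyond the scatter) and in place of 2,3-dimethylphenyl gives a 3.5-fold higher number from compound 1 to compound 4 (0.55 log units; beyond the scatter) in the same direction. The exchange between the two earlier groups gave only a 1.0-fold lower number from compound 1 to compound 3 (0.00 log units; within the scatter) so the flat result seen there does not extend to every substituted phenyl at this position. Nothing on hand gives a cause for this rise.

The compounds shown leave open whether one chlorine alone would give the same step, and how an unsubstituted phenyl would read here. They also leave open whether a phenyl carrying an amine or a carboxylic acid at this position would keep the lower numbers of compound 1 and compound 3.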